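This account rests on a few compounds, and the source may have more. Where it says the series, first, only, none or still open, it means among the compounds named here.

Values so far in a functional assay on P388 cells (Mus musculus); on this read-out higher numbers stand for weaker inhibition and lower numbers for stronger inhibition:

- Compound 1 `Cc1ccc(/C=C/C(=O)Oc2ccc(/C=C3\CCCC(CN(C)C)C3=O)cc2)cc1` gives 1290 nM
- Compound 2 `COc1ccc(C(=O)Oc2ccc(/C=C3\CCCCC3=O)cc2)cc1` gives > 50000 nM, which is a limit of the assay and not a number
- Compound 3 `CN(C)CC1CCC/C(=C\c2ccc(OC(=O)c3ccccc3)cc2)C1=O` gives 180 nM

Of the two true numbers in this assay, compound 3 holds the lower. Compound 4 `COc1ccc(C(=O)Oc2ccc(/C=C3\CCCC(CN(C)C)C3=O)cc2)cc1` changes compound 3 in one place: methoxy in place of hydrogen on an aromatic carbon, which turns phenyl into 4-methoxyphenyl. Going by the values given here, only one measured step bears on this. At the same end of the molecule, phenyl in place of 2-(4-methylphenyl)ethenyl gave a 7.2-fold lower number from compound 1 to compound 3 (0.86 log units; beyond the scatter). Adding methoxy is a smaller edit than that swap, so a smaller move toward a higher number is expected. The expected change is a 1.7-fold higher number from compound 3 to compound 4 (0.22 log units; within the scatter). The estimate for compound 4 is 300 nM, with an expected range of 100 nM to 1000 nM.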

Compound 4, half-maximal inhibitory concentration: 332 nM
Compound 4: the middle estimate sits 1.1-fold (0.04 log units) below what was measured, and the stated range covers the measured number.
By their numbers in this assay, from the lowest: compounds 3 and 4 (each within the scatter of the next); then compound 1. At a limit, above all of these: compound 2.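

In this assay, methoxy on the phenyl ring gives a 1.8-fold higher number from compound 3 to compound 4 (0.27 log units; within the scatter), so these two numbers cannot be told apart, and the ring accepts this added group. Going by these compounds alone, replacing 2-(4-methylphenyl)ethenyl with 4-methoxyphenyl gives a 3.9-fold lower number from compound 1 to compound 4 (0.59 log units; beyond the scatter), while adding (dimethylamino)methyl to the saturated ring gives the largest step so far, an at least 150-fold lower number from compound 2 to compound 4 (2.17 log units; beyond the scatter). Compound 2 stands at a limit of the assay, not a true number: the limit of > 50000 nM in this assay, at which 1 of the 4 values shown sits.

Going by these compounds, a single substituent cannot show a trend, so it remains open how a chlorine atom or a carboxylic acid would behave in place of methoxy. On these data alone, it is also open whether a cyclic amine such as piperidine could replace the dimethylamino part.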